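Benzyl swap from compound 3 to compound 4

The source may report more compounds than this note shows. Statements on the series, on what has been measured and on what is new or still open speak of the compounds shown alone.

In a functional assay on U-251 cells (Homo sapiens) for antiproliferative activity, read by MTT assay, with a stated time of 24 h (on this read-out lower numbers stand for stronger inhibition and higher numbers for weaker inhibition), compound 1 `C=CCOc1ccc2c(=O)c(-c3cc(OC)c(OC)cc3OC)coc2c1` gives 5900 nM and compound 2 `COc1cc(OC)c(-c2coc3cc(OCc4ccc(C#N)cc4)ccc3c2=O)cc1OC` gives 6180 nM. Compound 3 `COc1cc(OC)c(-c2coc3cc(OCc4ccccc4Br)ccc3c2=O)cc1OC` is recorded only as a limit, > 10000 nM, so it has no number to start from.

Compound 4 `COc1cc(OC)c(-c2coc3cc(OCc4ccc(C(F)(F)F)cc4)ccc3c2=O)cc1OC` differs from it as follows: 4-(trifluoromethyl)phenyl in place of 2-bromophenyl on a saturated chain carbon bound to an oxygen on an aromatic ring. In short, 4-(trifluoromethyl)phenyl stands in place of 2-bromophenyl on a saturated chain carbon bound to an oxygen on an aromatic ring.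

For the measured compounds named here, three measured steps bear on this change. The step of a 1.0-fold higher number from compound 1 to compound 2 (0.02 log units; within the scatter) lies within the scatter. The steps of an at least 1.6-fold higher number from compound 1 to compound 3 (0.22 log units; that floor lies within the scatter) and an at least 1.6-fold higher number from compound 2 to compound 3 (0.20 log units; that floor lies within the scatter) are floors that also lie within the scatter. Compound 2, with 4-cyanophenyl at the same place and a value of 6180 nM, is the closest reference. Only a small shift toward lower numbers is therefore expected in this assay, and it may not exceed the scatter.

The estimated shift is an at least 1.4-fold lower number from compound 3 to compound 4 (0.15 log units; that floor lies within the scatter).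

For compound 4 the expected value is 7000 nM, with an estimated range of 3500 nM to 10000 nM.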

Compound 4, half-maximal inhibitory concentration: 3750 nM
Estimate against measurement, compound 4: 1.9-fold (0.27 log units) above; the measured number falls inside the stated range.
By their numbers in this assay, from the lowest: compounds 4, 1 and 2 (each within the scatter of the next). At a limit, above all of these: compound 3.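

In this assay, for the compounds shown here, the change to 4-(trifluoromethyl)phenyl gives an at least 2.6-fold lower number from compound 3 to compound 4 (0.42 log units; beyond the scatter) and is the first step to pass the scatter, so the group on this saturated chain carbon can register in the read-out. Compound 4 still cannot be told apart from the other two measured compounds, with a 1.6-fold lower number from compound 2 to compound 4 (0.22 log units; within the scatter) for trifluoromethyl in place of cyano and a 1.6-fold lower number from compound 1 to compound 4 (0.20 log units; within the scatter) for the replacement of vinyl, so only compound 3 stands apart. Compound 3 is recorded as a limit, so that first step is a floor and its full size stays unknown: the limit of > 10000 nM in this assay, at which 1 of the 4 values shown sits.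

Only compound 3 carries 2-bromophenyl, so a single compound stands behind this separation. Going by these compounds, how an amine or a carboxylic acid on the phenyl ring, or a longer chain in place of the benzyl group, would read in this assay remains open.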